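Methoxy for Chloro on the Benzyl Ring

The source may report more compounds than this note shows. Statements on the series, on what has been measured and on what is new or still open speak of the compounds shown alone.

Compound 1, `COc1cc(OC)c(/C=C/S(=O)(=O)Cc2cc(OC)c(OC)c(OC)c2)c(OC)c1`, gives > 20000 nM, which is a limit of the assay rather than a number.
Compound 2, `COc1cc(OC)c(/C=C/S(=O)(=O)Cc2ccc(Cl)cc2)c(OC)c1`, gives 7500 nM.
Compound 3, `COc1ccc(CS(=O)(=O)/C=C/c2ccc(F)cc2Cl)cc1`, gives 2000 nM.

All three were tested in a functional assay on DU-145 cells (Homo sapiens) for antiproliferative activity, read by trypan blue exclusion; a lower number here means a stronger inhibitor, a higher number a weaker inhibitor. Compound 2 stands at the highest of the two numbers given; its nearest neighbour is compound 3, which sits at a lower number, and that gap is beyond the usual scatter. Compound 4, `COc1ccc(CS(=O)(=O)/C=C/c2c(OC)cc(OC)cc2OC)cc1`, has not yet been measured in this assay. It differs from compound 2 in one place: methoxy in place of chloro on an aromatic carbon. Cut one bond further out, the change reads 4-chlorophenyl to 4-methoxyphenyl. Within the data shown here, no measured pair shows this exact change on a shared core, so the size of the step cannot be read off directly. Compound 3 carries the 4-methoxyphenyl group with a different partner ring and sits at a lower number than compound 2, but the two differ in more than one place. The step from compound 2 to compound 4 is expected to be small, a 1.3-fold lower number from compound 2 to compound 4 (0.10 log units; within the scatter), with a wide range around it. For compound 4 the expected value is 6000 nM, between 1500 nM and 25000 nM.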

Compound 4, half-maximal inhibitory concentration: 25 nM
For compound 4 the middle estimate is 240-fold (2.38 log units) above the measured one; measured number outside the range, below it.
By their numbers in this assay, from the lowest: compound 4; then compound 3; then compound 2. At a limit, above all of these: compound 1.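

In this assay, among these compounds, methoxy in place of chloro on an aromatic carbon, para to a large group, gives a 300-fold lower number from compound 2 to compound 4 (2.48 log units; beyond the scatter) and so makes this single change a large one, which no earlier pair could show. The earlier compounds shown here held no matched pair at this place, and the result shows that activity on this core depends strongly on which of these two groups the position carries. Nothing measured here accounts for the size of the step.

As far as these compounds go, only chloro and methoxy can be compared at this position, so it remains open whether the step reflects something particular to methoxy or the loss of chloro. From the compounds shown here alone, how a hydroxyl, an amine, a fluoro or a longer alkoxy chain such as ethoxy would read at the same place on the shared core also remains open.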